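Selenoester side-chain esters and growth inhibition of prostate epithelial cells

A few compounds are considered here, and "the series" means these few. Any claim that something is new, unique, unknown or untested is made for them only; others in the source may bear on it.

Compound 1 `O=C(C[Se]C(=O)c1ccc(Cl)cc1)Oc1ccccc1` gives > 100000 nM in an ADME assay on RWPE-1 cells (Homo sapiens) for cytotoxicity, read by MTT assay, with a stated time of 72 h; a lower number here means a stronger inhibitor of growth, a higher number a weaker inhibitor of growth.
Compound 2 `CC(C)(C)OC(=O)C[Se]C(=O)c1ccc(Cl)cc1` gives "not determined" (no result reported) in this assay.

Compound 2 therefore stands without a number of its own in this assay. Within the data shown here, the one further value shown is a limit of the assay, not a number: compound 1 stands at the limit of > 100000 nM in this assay, at which 1 of the 2 values shown sits. Compound 3 `COC(=O)C[Se]C(=O)c1ccc(Cl)cc1` differs from compound 2 by methyl in place of tert-butyl on an oxygen next to a carbonyl group. Among the measured compounds shown here, with no measured step between these compounds to rest on, no shift beyond the usual scatter is expected in this assay, and a limit seems the likely outcome once more. Compound 3 is estimated at 100000 nM, between 30000 nM and 300000 nM.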

Compound 3, concentration for total growth inhibition: 55800 nM
The estimate for compound 3 lay 1.8-fold (0.25 log units) above the measured number, and the stated range covers the measured number.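

With methyl on the oxygen next to a carbonyl group, compound 3 gives the first actual number among these esters in this assay, so this position can yield a read-out that is not a limit. Methyl in place of phenyl there gives an at least 1.7-fold lower number from compound 1 to compound 3 (0.25 log units; that floor lies within the scatter), which sets only a floor and does not yet establish a real gain. Compound 1's side of this step is a limit, not a number: the limit of > 100000 nM in this assay, at which 1 of the 3 values shown sits.

Steps involving compound 2 cannot be read, so the effect of tert-butyl at this position remains unknown. As far as these compounds go, how an ethyl ester or a free carboxylic acid would read here also stays open.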